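Side-chain extension on the shared core: compound 3 to compound 4

The source may report more compounds than this note shows. Statements on the series, on what has been measured and on what is new or still open speak of the compounds shown alone.

In a functional assay on U-251 cells (Homo sapiens) for antiproliferative activity, read by sulforhodamine B assay, with a stated time of 48 h (a higher number here means a weaker inhibitor of growth, a lower number a stronger inhibitor of growth), compound 1 `COc1ccc2cc(CCCO)oc(=O)c2c1` gives 28.9 ug/mL. Compound 2 `COc1ccc2c(c1)C(=O)OC(CO)C2` reaches the assay limit, >= 250 ug/mL. Compound 3 `COc1ccc2c(c1)C(=O)OC(CCCO)C2` gives 135 ug/mL, the higher of the two numbers shown, with compound 1 sitting well below it; the only measured step is an at least 1.8-fold lower number from compound 2 to compound 3 (0.26 log units; that floor lies within the scatter). Compound 4 `CCCCCOCCCC1Cc2ccc(OC)cc2C(=O)O1` differs from compound 3 by pentyl in place of hydrogen on an oxygen on a saturated carbon. Within the data shown here, no measured step covers replacing the hydrogen on this oxygen by a chain; the step from compound 2 to compound 3 concerns chain length on carbon and its floor lies within the scatter, so it gives no firm direction. A modest step toward a lower number, a 1.9-fold lower number from compound 3 to compound 4 (0.29 log units; within the scatter), is therefore expected in this assay. Compound 4 is expected to give 70 ug/mL in this assay, between 20 ug/mL and 250 ug/mL.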

Compound 4, concentration for 50% growth inhibition: 32.2 ug/mL
Beside the measured number, compound 4's estimate is 2.2-fold (0.34 log units) above it, within the range that was stated.
By their numbers in this assay, from the lowest: compounds 1 and 4 (each within the scatter of the next); then compound 3. At a limit, above all of these: compound 2.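

Among these compounds, on the shared core, hydroxy to pentyloxy gives the first step beyond the scatter at this position in this assay, with a 4.2-fold lower number from compound 3 to compound 4 (0.62 log units; beyond the scatter). Pentyl in place of hydrogen on this oxygen is therefore tolerated, and the free hydroxy is not required for growth inhibition in this pair. Nothing at hand gives a cause for this step.

Going by these compounds, whether the step tracks the chain or the ether oxygen stays open: methoxy, a longer chain, or an amine in place of pentyloxy would separate these. On these data alone, the same change on the core of compound 1 also remains open.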